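Working notes: from compound 3 to compound 4

The compounds below may be only part of what the source reports. "The series", "measured", "known", "first", "only" and "open" are said of these compounds alone.

Measured in an ADME assay on HeLa cells (Homo sapiens) for cytotoxicity, read by MTT assay; on this read-out lower numbers stand for stronger inhibition and higher numbers for weaker inhibition:
- compound 1 `COc1ccc(C[C@H]2COC(=O)[C@@H]2Cc2ccc(OCc3cn(Cc4ccc(F)cc4)nn3)c(OC)c2)cc1OC`: 198000 nM
- compound 2 `COc1ccc(C[C@H]2COC(=O)[C@@H]2Cc2ccc(OCc3cn(-c4ccc(C)cc4)nn3)c(OC)c2)cc1OC`: >= 600000 nM (a limit)
- compound 3 `COc1ccc(C[C@H]2COC(=O)[C@@H]2Cc2ccc(OCC(=O)N3CCCC3)c(OC)c2)cc1OC`: >= 600000 nM (a limit)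

Compound 3 stands at >= 600000 nM, which is a limit and not a number. The series as a whole shows (the limit of >= 600000 nM in this assay, at which 2 of the 3 values shown sit). The next structure is compound 4 `COc1ccc(C[C@H]2COC(=O)[C@@H]2Cc2ccc(OCc3cn(-c4cccc(Cl)c4)nn3)c(OC)c2)cc1OC`, and the change is 1-(3-chlorophenyl)-1H-1,2,3-triazol-4-yl in place of (pyrrolidin-1-yl)carbonyl on a saturated chain carbon bound to an oxygen on an aromatic ring. In words, 1-(3-chlorophenyl)-1H-1,2,3-triazol-4-yl replaces (pyrrolidin-1-yl)carbonyl on a saturated chain carbon bound to an oxygen on an aromatic ring.

The nearest measured step is a step that the two limits leave unreadable from compound 2 to compound 3, an exchange of the opposite kind that gives no size. The other is an at least 3.0-fold higher number from compound 1 to compound 2 (0.48 log units; beyond the scatter), made on an aromatic nitrogen of the triazole. The closest relative of compound 4 is compound 2. Compound 2 gives only a limit, >= 600000 nM. Compound 1 shows that a triazole in this series can give a number, 198000 nM. No step beyond the scatter is therefore expected in this assay, and any movement is expected toward a lower number. The estimated step is an at least 1.3-fold lower number from compound 3 to compound 4 (0.12 log units; that floor lies within the scatter). For compound 4 the estimate is 450000 nM, with an expected range of 180000 nM to 900000 nM.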

Compound 4, half-maximal inhibitory concentration: 493000 nM
For compound 4 the middle estimate is 1.1-fold (0.04 log units) below the measured one, and the stated range covers the measured number.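

In this assay, a triazole carrying a phenyl ring directly on the aromatic nitrogen now gives a number and not a limit, but the exchange at the saturated chain carbon is only an at least 1.2-fold lower number from compound 3 to compound 4 (0.08 log units; that floor lies within the scatter), and the exchange on the aromatic nitrogen is only an at least 1.2-fold lower number from compound 2 to compound 4 (0.08 log units; that floor lies within the scatter). The step that can be read beyond the scatter is a 2.5-fold higher number from compound 1 to compound 4 (0.40 log units; beyond the scatter), which runs in the same direction as an at least 3.0-fold higher number from compound 1 to compound 2 (0.48 log units; beyond the scatter), and both steps replace 4-fluorobenzyl with a phenyl group. Two values remain limits and not numbers: the limit of >= 600000 nM in this assay, at which 2 of the 4 values shown sit.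

The compounds shown leave open whether 3-chlorophenyl and 4-methylphenyl truly differ, since one of the two values is a limit. Also open, from the compounds shown here alone, is how an amine or a carboxylic acid would read in place of these groups on the aromatic nitrogen.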